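A few compounds are considered here, and "the series" means these few. Any claim that something is new, unique, unknown or untested is made for them only; others in the source may bear on it.

Values in a functional assay for inhibition, with Homo sapiens as the target; on this read-out lower numbers stand for stronger inhibition and higher numbers for weaker inhibition:
- compound 1 `CCCCS(=O)(=O)N[C@@H](CNC(=O)c1ccc2c(c1)C(=O)N(CCC1CCNCC1)C2)C(=O)O`: 14 nM; 9 nM (2 entries)
- compound 2 `CCCCCS(=O)(=O)N[C@@H](CNC(=O)c1ccc2c(c1)C(=O)N(CCC1CCNCC1)C2)C(=O)O`: 9 nM
- compound 3 `CCCCCC(=O)N[C@@H](CNC(=O)c1ccc2c(c1)C(=O)N(CCC1CCNCC1)C2)C(=O)O`: 13 nM

Compound 3, at 13 nM, holds the highest single number of the set, but it stands within the scatter of compound 2, its nearest neighbour. The next compound, compound 4 `O=C(NC[C@H](NS(=O)(=O)c1ccccc1)C(=O)O)c1ccc2c(c1)C(=O)N(CCC1CCNCC1)C2`, carries phenylsulfonyl in place of pentylcarbonyl on an amine nitrogen.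

Among the compounds with values here, one measured step bears directly on this change, the exchange of pentylsulfonyl for pentylcarbonyl at the same nitrogen, which is a 1.4-fold higher number from compound 2 to compound 3 (0.16 log units; within the scatter). The repeat measurements set the spread to keep in mind: the several entries of compound 1 in this assay, 14 nM; 9 nM (2 entries). Within the data shown here, no measured compound carries phenylsulfonyl, so the sulfonyl half of the change has precedent in compound 2 at 9 nM, while the aromatic ring has none. No shift beyond the scatter is therefore expected in this assay, though the range is kept wide. The expected step is no change at the digits printed from compound 3 to compound 4 (within the scatter). For compound 4 the estimated value is 13 nM, with an expected range of 5 nM to 35 nM.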

Compound 4, half-maximal inhibitory concentration: 8 nM
For compound 4 the middle estimate is 1.6-fold (0.21 log units) above the measured one; the measured number falls inside the stated range.
By their numbers in this assay, from the lowest: compounds 4, 2 and 3 (each within the scatter of the next).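

In this assay, within the data shown here, an aromatic ring on this amine nitrogen's sulfonyl group leaves the read-out within the scatter, the first such evidence: the exchange of pentylcarbonyl for phenylsulfonyl gives a 1.6-fold lower number from compound 3 to compound 4 (0.21 log units; within the scatter), and phenyl in place of pentyl on the sulfonyl sulfur gives a 1.1-fold lower number from compound 2 to compound 4 (0.05 log units; within the scatter). At this position, then, the saturated chain of compound 2 and the six-membered aromatic ring of compound 4 cannot be told apart on these numbers. Neither step can be read as a gain, and the spread to set them against is that of the repeat entries: the several entries of compound 1 in this assay, 14 nM; 9 nM (2 entries).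

Open, from the compounds shown here alone, is whether a benzylsulfonyl group, or a phenyl ring bearing a chlorine or a methoxy group, would stay in the same range. So is whether a free amine at this nitrogen would do so.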